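This account rests on a few compounds, and the source may have more. Where it says the series, first, only, none or still open, it means among the compounds named here.

Three compounds have been run in a functional assay on cells (Cancer cell lines, Homo sapiens) for cytotoxicity, read by sulforhodamine B assay, with a stated time of 48 h; on this read-out higher numbers stand for weaker inhibition of growth and lower numbers for stronger inhibition of growth. Compound 1 `COc1ccc(OC)c(-c2cc(-c3ccccc3)nn2-c2ccc(S(=O)(=O)NC(C)=O)cc2)c1` gives 9700 nM in this assay. Compound 2 `COc1ccc(OC)c(-c2cc(-c3ccc(Cl)cc3)nn2-c2ccc(S(=O)(=O)NC(C)=O)cc2)c1` carries chloro in place of hydrogen on an aromatic carbon and gives 25500 nM in this assay; the step is a 2.6-fold higher number from compound 1 to compound 2 (0.42 log units; beyond the scatter). Compound 3 `NS(=O)(=O)c1ccc(-n2nc(-c3ccccc3)cc2-c2cc(O)ccc2O)cc1` rests on a different core, and the difference between the core of compound 1 and the core of compound 3 is not broken down here. In this assay compound 3 gives 83900 nM, the highest of the three numbers, its steps to compound 2 and to compound 1 both lying beyond the scatter.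

Compound 4 `NS(=O)(=O)c1ccc(-n2nc(-c3ccc(Cl)cc3)cc2-c2cc(O)ccc2O)cc1` has not yet been measured. It differs from compound 3 by chloro in place of hydrogen on an aromatic carbon, the same change that separates compound 1 from compound 2. Because the earlier step of a 2.6-fold higher number from compound 1 to compound 2 (0.42 log units; beyond the scatter) was modest, a comparable step is expected on the core of compound 3. Compound 4 is therefore expected to shift by a 2.4-fold higher number from compound 3 to compound 4 (0.38 log units; beyond the scatter). Compound 4 is estimated at about 200000 nM in this assay, with 90000 nM to 450000 nM as the likely range, and there is a real chance that the assay reports only a limit for compound 4.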

Compound 4, concentration for 50% growth inhibition: 16700 nM
Compound 4: the middle estimate sits 12-fold (1.08 log units) above what was measured; measured number outside the range, below it.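

In this assay, putting chloro in place of hydrogen on this core gives a 5.0-fold lower number from compound 3 to compound 4 (0.70 log units; beyond the scatter), a move towards stronger inhibition of growth, whereas the same change moved the other core towards weaker inhibition. The two steps therefore run in opposite directions and do not match: the same change on two cores in this assay, a 2.6-fold higher number (0.42 log units; beyond the scatter) from compound 1 to compound 2 and a 5.0-fold lower number (0.70 log units; beyond the scatter) from compound 3 to compound 4, 13-fold (1.12 log units) apart, beyond the scatter of two such steps

This shows that, within these two pairs, the effect of going from phenyl to 4-chlorophenyl cannot be carried from one core to the other, but it does not show which difference between the cores goes with the reversal, and two pairs set no rule for the wider series.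

The cores differ both in the acetyl group on the sulfonamide and in the methoxy groups that stand where compound 3 has hydroxyl groups, and the compounds shown do not separate these two differences. Also left open is how another group in the same place, such as fluoro or an amine, would behave on either core.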